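This account rests on a few compounds, and the source may have more. Where it says the series, first, only, none or still open, it means among the compounds named here.

Measured in a functional assay on HL-60 cells (Homo sapiens) for cytotoxicity, read by MTT assay, with a stated time of 24 h; a higher number here means a weaker inhibitor, a lower number a stronger inhibitor:
compound 1 `BrCCCOc1c(Br)cc(Br)cc1Oc1ccc(Br)cc1Br`: 29.9 ug/mL
compound 2 `CN1CCN(CCCCCOc2c(Br)cc(Br)cc2Oc2ccc(Br)cc2Br)CC1`: 48.3 ug/mL
compound 3 `BrCCOc1c(Br)cc(Br)cc1Oc1ccc(Br)cc1Br`: 26.2 ug/mL

Compound 3 sits level with the other two, with a 1.1-fold lower number from compound 1 to compound 3 (0.06 log units; within the scatter) and a 1.8-fold lower number from compound 2 to compound 3 (0.27 log units; within the scatter). Compound 4 `OCCOc1c(Br)cc(Br)cc1Oc1ccc(Br)cc1Br` has hydroxy in place of bromo on a saturated chain carbon, two bonds along the chain from an oxygen on an aromatic ring. Within the data shown here, no measured step makes this exact exchange. The nearest evidence is other changes at the chain end, including a 1.6-fold higher number from compound 1 to compound 2 (0.21 log units; within the scatter), and all three steps stay within the scatter. No step beyond the scatter is therefore expected in this assay, and no direction is favoured. The expected step is a 1.1-fold higher number from compound 3 to compound 4 (0.06 log units; within the scatter). The estimate for compound 4 is 30 ug/mL, with an expected range of 14 ug/mL to 62 ug/mL.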

Compound 4, half-maximal inhibitory concentration: 28.2 ug/mL
For compound 4 the middle estimate is 1.1-fold (0.03 log units) above the measured one, and the stated range covers the measured number.
By their numbers in this assay, from the lowest: compounds 3, 4, 1 and 2 (each within the scatter of the next).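

In this assay, hydroxy at this chain position, which adds a hydrogen-bond donor and acceptor where bromo had none, leaves the number within the scatter (a 1.1-fold higher number from compound 3 to compound 4 (0.03 log units; within the scatter)). Compound 4 also stays within the scatter of the other two chain ends (a 1.1-fold lower number from compound 1 to compound 4 (0.03 log units; within the scatter); a 1.7-fold lower number from compound 2 to compound 4 (0.23 log units; within the scatter)), so a terminal halogen is not needed for this level of cytotoxicity among these compounds. No supporting measurement bears on this result. From the compounds shown here alone, an amine or a carboxylic acid on the two-carbon chain remains open, as does a longer chain ending in hydroxy.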